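Two hydroxypropyl chains in place of two methyl groups

A few compounds are considered here, and "the series" means these few. Any claim that something is new, unique, unknown or untested is made for them only; others in the source may bear on it.

Compound 1 `CN(C)c1ccc(NC(=O)c2cc(Cl)ccc2O)c(Cl)c1` was tested in an ADME assay on A549 cells (Homo sapiens) for cytotoxicity, read by resazurin assay, with a stated time of 48 h (a higher number here means that more compound is tolerated, a lower number that less compound is tolerated), and gave 85100 nM. This is the higher of the two numbers recorded so far: compound 2 `CN(C)c1ccc(CNc2ccc(NC(=O)c3cc(Cl)ccc3O)c(Cl)c2)cc1`, a larger relative, gives 24500 nM in this assay, and the gap between the two lies beyond the usual scatter, so compound 1 is the better tolerated of the pair. Compound 3 `O=C(Nc1ccc(N(CCCO)CCCO)cc1Cl)c1cc(Cl)ccc1O` has not yet been measured. It differs from compound 1 in a single place: bis(3-hydroxypropyl)amino in place of dimethylamino on an aromatic carbon. Among the measured compounds shown here, no measured pair shows this kind of change, so the direction of the step is open. Compound 2 shows that one larger relative was tolerated less well, but the bis(3-hydroxypropyl)amino group is a different kind of enlargement. The step from compound 1 to compound 3 is expected to stay within the scatter: a 1.1-fold higher number from compound 1 to compound 3 (0.02 log units; within the scatter). Compound 3 is therefore estimated at 90000 nM, with a range from 35000 nM to 230000 nM.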

Compound 3, half-maximal cytotoxic concentration: 114000 nM
Beside the measured number, compound 3's estimate is 1.3-fold (0.10 log units) below it; measured number inside the range.
By their numbers in this assay, from the lowest: compound 2; then compounds 1 and 3 (each within the scatter of the next).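

In this assay, putting bis(3-hydroxypropyl)amino in place of dimethylamino gives a 1.3-fold higher number from compound 1 to compound 3 (0.13 log units; within the scatter). This position, on an aromatic carbon para to a large group and meta to a chloro group, can therefore carry a group of 9 heavy atoms with 2 hydrogen-bond donors instead of one of 3 heavy atoms with none, and any effect on how well the compound is tolerated cannot be told from the scatter. No measurement shown here explains this result.

The compounds shown do not separate the effect of the chain length from that of the hydroxyl groups at the chain ends. A dipropylamino group, with the same length of chain but no oxygen, would address that, and a carboxylic acid at the chain ends would test a different end group.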